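Saturating the linker of compound 2

This account rests on a few compounds, and the source may have more. Where it says the series, first, only, none or still open, it means among the compounds named here.

compound 1 `CC1CN(C(=O)c2ccc(-c3ccc(NC(=O)Nc4ccc(Cl)c(C(F)(F)F)c4)cc3)cc2)CC(C)O1` gives 2050 nM
compound 2 `O=C(/C=C/c1ccc(NC(=O)Nc2ccc(Cl)c(C(F)(F)F)c2)cc1)NC1CCC1` gives 4430 nM
compound 3 `CC(NC(=O)c1ccc(-c2ccc(NC(=O)Nc3cc(C(F)(F)F)ccc3Cl)cc2)cc1)c1ccccc1` gives 6570 nM

These three values all come from a functional assay on HT-29 cells (Homo sapiens) for inhibition, read by MTT assay, with a stated time of 120 h (on this read-out higher numbers stand for weaker inhibition and lower numbers for stronger inhibition), and they span a fairly narrow range. Compound 2 (4430 nM) lies within the usual scatter of compound 3 (6570 nM) in this read-out. The gap between compound 2 and compound 1 (2050 nM) goes beyond the scatter, with compound 1 holding the lower number and so the stronger inhibition.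

Compound 4 `O=C(CCc1ccc(NC(=O)Nc2ccc(Cl)c(C(F)(F)F)c2)cc1)NC1CCC1` has not yet been measured. It differs from compound 2 in one place, where 2-(cyclobutylcarbamoyl)ethyl stands in place of 2-(cyclobutylcarbamoyl)ethenyl on an aromatic carbon, para to a large group (2-(cyclobutylcarbamoyl)ethyl in place of 2-(cyclobutylcarbamoyl)ethenyl on an aromatic carbon). The rest of the structure stays the same.

Within the data shown here, no two measured compounds differ in only one place, so the data do not size this change directly. The expectation therefore starts from compound 2 (4430 nM) and foresees no step beyond the scatter in this assay in either direction. The expected step (a 1.1-fold higher number from compound 2 to compound 4 (0.03 log units; within the scatter)) is accordingly small. For compound 4 the estimate is 4800 nM with an expected range from 2000 nM to 11000 nM in this read-out.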

Compound 4, half-maximal inhibitory concentration: 21300 nM
Compound 4: middle estimate off by 4.4-fold (0.65 log units), on the low side, outside the stated range (above it).
By their numbers in this assay, from the lowest: compound 1; then compounds 2 and 3 (each within the scatter of the next); then compound 4.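

Among these compounds, compound 4 gives the first direct reading at this position, and it shows that the 2-(cyclobutylcarbamoyl)ethenyl group cannot be exchanged freely for 2-(cyclobutylcarbamoyl)ethyl in this assay (a 4.8-fold higher number from compound 2 to compound 4 (0.68 log units; beyond the scatter)). This step lies beyond the scatter and goes towards weaker inhibition, so the position on the aromatic carbon, para to a large group, is sensitive to this change. The two groups have the same counts of heavy atoms, hydrogen-bond donors and hydrogen-bond acceptors and the same four-membered ring, and they differ in the count of double bonds outside aromatic rings; nothing measured here explains the loss of inhibition.

The compounds shown leave open whether the same step would appear with a piperidine amide in place of the cyclobutyl amide, as this single pair sizes the change with only one amide. They also leave open where a longer chain, such as 3-(cyclobutylcarbamoyl)propyl, or a carboxylic acid at the end of the ethyl chain, would fall relative to compound 4 in this assay.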